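Aryl variation on the imidazopyrazine-benzimidazole series

The source may hold more compounds than are shown below. What is called first, only, known or untested is meant among the compounds shown, and "the series" means these compounds.

Compound 1 `Brc1cn2ccnc2c(-c2ccc3ncn(C4CCCCC4)c3c2)n1`: 22.5%
Compound 2 `c1ccc(-c2cn3ccnc3c(-c3ccc4ncn(C5CCCCC5)c4c3)n2)cc1`: 33.9%
Compound 3 `Fc1ccc(-c2cn3ccnc3c(-c3ccc4ncn(C5CCCCC5)c4c3)n2)cc1`: 23.3%

In a functional assay on NCI-H226 cells (Homo sapiens) for inhibition, read by sulforhodamine B assay, with a stated time of 48 h, tested at 10 uM (on this read-out lower numbers stand for less inhibition and higher numbers for more inhibition at the one concentration tested (going by the name of the read-out)), compound 2 stands highest of the three, with both neighbours beyond the scatter: a number 11.4 percentage points higher from compound 1 to compound 2 (beyond the scatter) and a number 10.6 percentage points lower from compound 2 to compound 3 (beyond the scatter), while a number 0.8 percentage points higher from compound 1 to compound 3 (within the scatter).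

Compound 4 `c1csc(-c2cn3ccnc3c(-c3ccc4ncn(C5CCCCC5)c4c3)n2)c1` keeps the shared core and changes only the aryl group: thiophen-2-yl in place of phenyl on an aromatic carbon. Among the measured compounds shown here, no measured step swaps one aromatic ring for another of a different kind; the nearest information is that the aryl ring itself matters modestly, as a number 11.4 percentage points higher from compound 1 to compound 2 (beyond the scatter) shows, and that a small change on it can cost a modest amount, as a number 10.6 percentage points lower from compound 2 to compound 3 (beyond the scatter) shows. The step from compound 2 to compound 4 is therefore expected to be small, possibly a modest drop, and not clearly beyond the scatter: a number 4.9 percentage points lower from compound 2 to compound 4 (within the scatter). Compound 4 is expected to give about 29%, within 15% to 43%.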

Compound 4, a percentage reported as inhibition, at one concentration (the size of the read-out at that concentration, not a potency): 17.1%
Estimate against measurement, compound 4: 11.9 percentage points above, and the stated range covers the measured number.
By their numbers in this assay, from the lowest: compounds 4, 1 and 3 (each within the scatter of the next); then compound 2.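

In this assay, the kind of aromatic ring at this position counts, not just the presence of one: a number 16.8 percentage points lower from compound 2 to compound 4 (beyond the scatter). The gain seen with phenyl over bromo does not carry over to thiophen-2-yl, with a number 5.4 percentage points lower from compound 1 to compound 4 (within the scatter), and thiophen-2-yl also stays level with 4-fluorophenyl, with a number 6.2 percentage points lower from compound 3 to compound 4 (within the scatter), so only compound 2 stands apart among these four. Nothing available explains why phenyl stands apart here. Open, going by these compounds, is how an amine or a carboxylic acid on the phenyl ring would compare with compound 2, and whether a pyridinyl ring at this position would stand with phenyl or with thiophen-2-yl.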